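The source may report more compounds than this note shows. Statements on the series, on what has been measured and on what is new or still open speak of the compounds shown alone.

Measured in a physicochemical assay for lipophilicity, at pH 7.4; on this read-out higher numbers stand for higher lipophilicity and lower numbers for lower lipophilicity:
compound 1 `CCOc1ccc2c(c1)C(c1cnn(C)c1)=CN(C)C(=O)[C@@H]2C`: 4.1
compound 2 `CCOc1ccc2c(c1)C(c1cn[nH]c1)=CN(C)C(=O)[C@@H]2C`: 3.4
compound 3 `CCOc1ccc2c(c1)C(c1cn(C)cn1)=CN(C)C(=O)[C@@H]2C`: 3.6

Compound 2 stands at the low end of this short series, together with compound 3: a number 0.20 log units higher from compound 2 to compound 3 (within the scatter), against a number 0.70 log units lower from compound 1 to compound 2 (beyond the scatter).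

Compound 4 `C[C@H]1C(=O)N(C)C=C(c2cn[nH]c2)c2cc([C@H](O)CO)ccc21`, not yet measured, carries 1,2-dihydroxyethyl in place of ethoxy on an aromatic carbon. Within the data shown here, no measured step touches the ethoxy, so the steps bear only as a scale, and a number 0.50 log units lower from compound 1 to compound 3 (beyond the scatter) is modest. Going by the hydrogen-bond donors that enter, a step to a lower number is expected, clearly larger than a number 0.70 log units lower from compound 1 to compound 2 (beyond the scatter). The expected step is a number 1.70 log units lower from compound 2 to compound 4 (beyond the scatter). The estimate for compound 4 is 1.7, with an expected range from 1.1 to 2.3.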

Compound 4, distribution coefficient: 0.8
Estimate against measurement, compound 4: 0.90 log units above, outside the stated range (below it).
By their numbers in this assay, from the lowest: compound 4; then compounds 2 and 3 (each within the scatter of the next); then compound 1.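

Among these compounds, this is the first measured change on the six-membered aromatic ring of carbon only, and in this assay 1,2-dihydroxyethyl in place of ethoxy gives a number 2.60 log units lower from compound 2 to compound 4 (beyond the scatter) as a large step. The read-out at this aromatic carbon therefore moves much further than in a number 0.70 log units lower from compound 1 to compound 2 (beyond the scatter) at the aromatic nitrogen. Nothing available accounts for the size of this step.

A single hydroxyethyl chain, a methoxyethyl chain or an amine at this carbon would show how much of the step needs both hydroxyl groups. Going by these compounds, whether the same step holds with the 1-methyl-1H-pyrazol-4-yl group stays open.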